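A few compounds are considered here, and "the series" means these few. Any claim that something is new, unique, unknown or untested is made for them only; others in the source may bear on it.

Three compounds that differ only in one group on the shared core have been measured in a physicochemical assay for solubility, in phosphate buffer, at pH 7.4; on this read-out higher numbers stand for higher solubility and lower numbers for lower solubility. Compound 1 `CC(=O)N[C@@H]1CCC[C@H](C(=O)Nc2cc(-c3cnc(C)n3C)c(Cl)cn2)C1` gives > 1000000 nM, which is a limit of the assay and not a number. Compound 2 `CC(=O)N[C@@H]1CCC[C@H](C(=O)Nc2cc(-c3nnn4ccccc34)c(Cl)cn2)C1` gives 530000 nM. Compound 3 `CC(=O)N[C@@H]1CCC[C@H](C(=O)Nc2cc(-c3cnn4c3COCC4)c(Cl)cn2)C1` gives 220000 nM, the lowest reading of the three.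

Compound 4 `CC(=O)N[C@@H]1CCC[C@H](C(=O)Nc2cc(-c3cnn4c3CC(C)(C)C4)c(Cl)cn2)C1` keeps the core of compound 3 and changes one group: a group of 10 heavy atoms (8 carbon, 2 nitrogen; one five-membered non-aromatic ring with 1 hetero atom, one five-membered aromatic ring with 2 hetero atoms) in place of a group of 9 heavy atoms (6 carbon, 2 nitrogen, 1 oxygen; one five-membered aromatic ring with 2 hetero atoms, one six-membered non-aromatic ring with 2 hetero atoms), on an aromatic carbon. The entering group carries no oxygen, and its non-aromatic ring is five-membered rather than six-membered.

For the measured compounds named here, no measured step isolates this exact swap, but three steps at the same place offer a guide. The step of a 2.4-fold lower number from compound 2 to compound 3 (0.38 log units; beyond the scatter) exchanges one fused group for another and is modest. The step of an at least 4.5-fold lower number from compound 1 to compound 3 (0.65 log units; beyond the scatter) replaces a single ring with a larger group, and the number falls. The step of an at least 1.8-fold lower number from compound 1 to compound 2 (0.27 log units; that floor lies within the scatter) makes a similar replacement, but its floor lies within the scatter. Taken together, these steps suggest that changes at this place tend to be moderate, and that larger groups here have so far given lower numbers.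

A small downward change is therefore expected, a 1.5-fold lower number from compound 3 to compound 4 (0.17 log units; within the scatter). The estimated value for compound 4 is 150000 nM, with an expected range from 50000 nM to 450000 nM.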

Compound 4, solubility: 150000 nM
Beside the measured number, compound 4's estimate shows no gap at the digits printed; measured number inside the range.
By their numbers in this assay, from the lowest: compounds 4 and 3 (each within the scatter of the next); then compound 2. At a limit, above all of these: compound 1.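

In this assay, the step of a 1.5-fold lower number from compound 3 to compound 4 (0.17 log units; within the scatter) shows that, on this aromatic carbon opposite the ring nitrogen, a group with no oxygen and a five-membered non-aromatic ring does not separate from the oxygen-bearing group with a six-membered non-aromatic ring. The wider comparison is clearer, for the step of a 3.5-fold lower number from compound 2 to compound 4 (0.55 log units; beyond the scatter) puts compound 4 apart from compound 2, so compounds 3 and 4 now form a pair of two different fused groups that both read under compound 2. The step of an at least 6.6-fold lower number from compound 1 to compound 4 (0.82 log units; beyond the scatter) gives only a floor, since compound 1 gives a limit and not a number: the limit of > 1000000 nM in this assay, at which 1 of the 4 values shown sits.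

Oxygen and ring size change together between compound 3 and compound 4, so these compounds cannot say what either change does alone, and a small step within the scatter could hide opposing contributions. Also open is how this reading would respond to a fused group carrying an amine or a carboxylic acid, or to a longer chain on the non-aromatic ring, since every group shown here has neither.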